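Swapping One Aromatic Group for Another on the Same Chain

A few compounds are considered here, and "the series" means these few. Any claim that something is new, unique, unknown or untested is made for them only; others in the source may bear on it.

Of the compounds shown here, two have been measured in a functional assay on L1210 cells (Mus musculus) for inhibition; a higher number here means a weaker inhibitor, a lower number a stronger inhibitor. Compound 1 `COc1cccc(OC/C=C(\C)CC/C=C(\C)C2CC(=O)C(C)(C)O2)c1` gives 66.5 ug/mL. Compound 2 `C/C(=C\COc1c(Cl)cccc1Cl)CC/C=C(\C)C1=CC(=O)C(C)(C)O1` gives 30.7 ug/mL. Compound 2 therefore holds the lower of the two numbers, and the gap to compound 1 lies beyond the usual scatter, so compound 2 counts as the stronger inhibitor of the pair. Compound 1 and compound 2 differ from each other in more than one place, so these two numbers alone do not show which part of the structure accounts for the gap.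

Compound 3 `COc1cccc(OC/C=C(\C)CC/C=C(\C)C2=CC(=O)C(C)(C)O2)c1` has not yet been measured. It differs from compound 2 in a single place: 3-methoxyphenyl in place of 2,6-dichlorophenyl on an oxygen on a saturated carbon. The 3-methoxyphenyl group is the same one that compound 1 carries, but compound 1 also differs from compound 3 elsewhere, so the measurement of compound 1 cannot settle what this change alone does. Among the measured compounds shown here, with no measured step of this exact kind in hand, the expected step is modest, a 1.5-fold higher number from compound 2 to compound 3 (0.17 log units; within the scatter), leaning slightly toward a weaker inhibitor. Compound 3 is accordingly estimated at 45 ug/mL, with a range from 15 ug/mL to 120 ug/mL.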

Compound 3, half-maximal inhibitory concentration: 36.3 ug/mL
Compound 3: middle estimate off by 1.2-fold (0.09 log units), on the high side; low and high end bracket the measured number.
By their numbers in this assay, from the lowest: compounds 2, 3 and 1 (each within the scatter of the next, the first and the last beyond it).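

In this assay, putting 3-methoxyphenyl in place of 2,6-dichlorophenyl on an oxygen on a saturated carbon gives a 1.2-fold higher number from compound 2 to compound 3 (0.07 log units; within the scatter), so these two aromatic groups of 8 heavy atoms cannot be told apart at this position, even though one carries two chlorine atoms and the other carries an oxygen. Compound 3 also links to compound 1 through a single change, an exchange between two groups of 8 heavy atoms, each with one five-membered non-aromatic ring, on a double-bonded chain carbon; this gives a 1.8-fold lower number from compound 1 to compound 3 (0.26 log units; within the scatter), so neither single change shown here lies beyond the scatter. Nothing available explains why either group gives the number it does.

Among the compounds shown here, only two aromatic groups have been compared at this position, so a plain phenyl, a pyridine ring or an aromatic ring bearing an amine or a carboxylic acid could behave quite differently. From the compounds shown here alone, it also remains open whether the same small steps would hold with a shorter or longer chain, or with the aromatic group exchanged on the core of compound 1.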